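This account rests on a few compounds, and the source may have more. Where it says the series, first, only, none or still open, it means among the compounds named here.

Compound 1 `COc1cc2ncnc(Nc3cccc(Br)c3)c2cc1OCCCCC(=O)Nc1ccc(S(N)(=O)=O)cc1` and compound 2 `COc1cc2ncnc(Nc3cccc(Cl)c3)c2cc1OCCCCC(=O)Nc1ccc(S(N)(=O)=O)cc1` share one core and differ only in the halogen on the aniline ring. In a functional assay on A-431 cells (Homo sapiens) for antiproliferative activity, read by MTT assay, with a stated time of 72 h (a lower number here means a stronger inhibitor, a higher number a weaker inhibitor), compound 1 gives 9750 nM, while compound 2 gives 30400 nM, so compound 2 carries the higher of the two numbers and is therefore the weaker inhibitor of this pair; the difference, a 3.1-fold higher number from compound 1 to compound 2 (0.49 log units; beyond the scatter), is modest but real. Compound 3 `COc1cc2ncnc(Nc3ccc(F)c(Br)c3)c2cc1OCCCCC(=O)Nc1ccc(S(N)(=O)=O)cc1` has not yet been measured. It differs from compound 2 by 3-bromo-4-fluorophenyl in place of 3-chlorophenyl on a nitrogen on an aromatic ring. For the measured compounds named here, the only measured step that bears on this change is the swap from bromo to chloro, a 3.1-fold higher number from compound 1 to compound 2 (0.49 log units; beyond the scatter); reversing it, bromo in place of chloro, should move the number back toward that of compound 1, while nothing among the measured compounds tells how the added fluorine acts. Compound 3 is therefore expected to give about 7000 nM, within 2000 nM to 25000 nM, a step of a 4.3-fold lower number from compound 2 to compound 3 (0.64 log units; beyond the scatter).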

Compound 3, half-maximal inhibitory concentration: 8020 nM
Beside the measured number, compound 3's estimate is 1.1-fold (0.06 log units) below it; the measured number falls inside the stated range.
By their numbers in this assay, from the lowest: compounds 3 and 1 (each within the scatter of the next); then compound 2.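

Compound 3 brings back the bromo and adds a fluoro, and together these changes give a 3.8-fold lower number from compound 2 to compound 3 (0.58 log units; beyond the scatter) in this assay. The new information is that fluoro in place of hydrogen on an aromatic carbon gives a 1.2-fold lower number from compound 1 to compound 3 (0.08 log units; within the scatter), so with bromo present, this assay cannot distinguish the fluoro compound from the one without it, and the advantage of compound 3 over compound 2 appears to track the bromo rather than the fluoro. No measurement is available to explain why either halogen change behaves as it does.

On these data alone, it remains open whether fluoro in place of hydrogen would also make no clear difference in a compound carrying chloro instead of bromo. As far as these compounds go, how an iodo or a methyl group would compare with bromo and chloro on this ring is also open.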